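Cyclopentenone series: cytotoxicity notes toward compound 4

The source may report more compounds than this note shows. Statements on the series, on what has been measured and on what is new or still open speak of the compounds shown alone.

Measured compounds:
compound 1 `COc1ccc(C2=C(c3cc(OC)c(OC)c(OC)c3)C(=O)C(O)C2)cc1NC(=O)c1ccccc1` — > 100 ug/mL
compound 2 `COc1ccc(C2=C(c3cc(OC)c(OC)c(OC)c3)C(=O)C(OC(C)=O)C2)cc1OC(C)C` — > 100 ug/mL
compound 3 `CC(=O)OC1C/C(=N/O)C(c2ccccc2)=C1c1ccccc1` — 92.3 ug/mL

Three compounds of the series have been run in an ADME assay on HEK293 cells (Homo sapiens) for cytotoxicity, read by MTT assay, with a stated time of 72 h; a lower number here means a stronger inhibitor, a higher number a weaker inhibitor. Compound 1 gives only a limit, > 100 ug/mL, not a number. Compound 2 likewise reports only a limit, > 100 ug/mL. Compound 3 gives a number, 92.3 ug/mL, in this assay. Where compound 1 stands can therefore only be said as the limit of > 100 ug/mL in this assay, at which 2 of the 3 values shown sit; no step between two measured compounds that differ in a single place is available, so no measured step size exists to lean on.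

The next compound, compound 4 `COc1ccc(C2=C(c3cc(OC)c(OC)c(OC)c3)C(=O)C(O)C2)cc1Cl`, differs from compound 1 in one place: chloro in place of benzamido on an aromatic carbon. Within the data shown here, with no measured step to calibrate against, the expectation rests only on the fact that compound 1 sits at the limit of this assay and compound 2 sits there too. For compound 4 the estimate is 100 ug/mL, within 45 ug/mL to 220 ug/mL. The expected step from compound 1 to compound 4, a number no higher from compound 1 to compound 4 (the limit leaves the size open), is taken as none beyond the scatter in this assay, with a fair chance that the assay again reports only a limit.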

Compound 4, half-maximal inhibitory concentration: > 100 ug/mL
Compound 4 gave a limit, no number; the forecaster's own chance of this, stated with the estimate: 60%; the middle value sits exactly at the limit.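

Compound 1 and compound 4 each give only a limit in this assay, not a number, so no step can be read between them. Compound 4 joins the values at that limit: the limit of > 100 ug/mL in this assay, at which 3 of the 4 values shown sit.

The compounds shown leave open whether chloro and benzamido on this aromatic carbon differ at all in this assay.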